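The source may hold more compounds than are shown below. What is called first, only, known or untested is meant among the compounds shown, and "the series" means these compounds.

In a functional assay on KG-1 cells (Homo sapiens) for cytotoxicity, read by luminescence and CellTiter-Glo, with a stated time of 3 days (on this read-out lower numbers stand for stronger inhibition and higher numbers for weaker inhibition), compound 1 `N#Cc1ccc(NC(=O)c2cc(-c3ccccc3)ccc2O)cc1` gives 1300 nM. Going by the values given here, compound 2 `N#Cc1ccc(NC(=O)c2cc(Cl)ccc2O)cc1` gives 1860 nM, which lies within the scatter of compound 1, the only other measured member of the series. Compound 3 `N#Cc1ccc(NC(=O)c2ccccc2O)cc1` has not yet been measured. Its difference from compound 2 is hydrogen in place of chloro on an aromatic carbon, para to a hydroxy group. Among the compounds with values here, one measured step bears on this carbon: a 1.4-fold higher number from compound 1 to compound 2 (0.16 log units; within the scatter), with chloro in place of phenyl. Within the data shown here, that step stays within the scatter, so the one exchange seen at this carbon has not separated the two compounds in this assay. Among the measured compounds shown here, it is a single pair, however, and no compound carrying only hydrogen at this carbon has been measured, so the expectation is loose. Going by these compounds, no step beyond the scatter is expected, and the direction remains open, with a small allowance toward a higher number. For compound 3, the expected value is about 2400 nM, with an estimated range of 1000 nM to 6000 nM. This estimate corresponds to an expected 1.3-fold higher number from compound 2 to compound 3 (0.11 log units; within the scatter).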

Compound 3, half-maximal inhibitory concentration: 5370 nM
Compound 3: the middle estimate sits 2.2-fold (0.35 log units) below what was measured; low and high end bracket the measured number.
By their numbers in this assay, from the lowest: compounds 1 and 2 (each within the scatter of the next); then compound 3.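

In this assay, the carbon para to a hydroxy group now proves to matter: hydrogen in place of chloro gives a 2.9-fold higher number from compound 2 to compound 3 (0.46 log units; beyond the scatter) and hydrogen in place of phenyl gives a 4.1-fold higher number from compound 1 to compound 3 (0.62 log units; beyond the scatter) so compound 3, with neither group, is the weakest of the three compounds. Chloro and phenyl, which could not be told apart from each other, are therefore both separated from hydrogen, and the single chlorine atom is enough to reach the range of the larger group in this series. Nothing at hand accounts for why either group gives a lower number than hydrogen.

Going by these compounds, whether any group at this carbon would give the same lower numbers, or only these two, stays open; a methoxy group, an amine or a carboxylic acid there would test this. Also open, on these data alone, is whether the same step from hydrogen would hold if the nitrile or the hydroxy group of the shared core were replaced, as all three compounds keep both unchanged.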